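Sulfonyl ring variants: working notes

This account rests on a few compounds, and the source may have more. Where it says the series, first, only, none or still open, it means among the compounds named here.

compound 1 `COC(=O)NC(=O)c1ccsc1NC(=O)c1ccc(S(=O)(=O)N2CCC2)cc1` gives 17.5 ug/mL
compound 2 `COC(=O)NC(=O)c1ccsc1NC(=O)c1ccc(S(=O)(=O)N2CCC(C)CC2)cc1` gives 9.13 ug/mL

In a toxicity assay on Vero cells (Chlorocebus sabaeus) for cytotoxicity, read by MTT assay (on this read-out lower numbers stand for stronger inhibition and higher numbers for weaker inhibition), compound 2 at 9.13 ug/mL lies within the scatter of compound 1. Compound 3 `COC(=O)NC(=O)c1ccsc1NC(=O)c1ccc(S(=O)(=O)N2CCC(OC)CC2)cc1` differs from compound 2 by methoxy in place of methyl on a saturated ring carbon in the group on the sulfonyl sulfur, methoxy in place of methyl on a saturated ring carbon. For the measured compounds named here, the one measured step bearing on this is a 1.9-fold lower number from compound 1 to compound 2 (0.28 log units; within the scatter) for a change of group on that same sulfur, and it stays within the scatter. No step beyond the scatter is therefore expected in this assay and the estimated step of a 1.3-fold higher number from compound 2 to compound 3 (0.12 log units; within the scatter) stays small. Compound 3 is estimated at 12 ug/mL (range 5 ug/mL to 30 ug/mL).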

Compound 3, half-maximal inhibitory concentration: 18 ug/mL
Beside the measured number, compound 3's estimate is 1.5-fold (0.18 log units) below it, and the stated range covers the measured number.
By their numbers in this assay, from the lowest: compounds 2, 1 and 3 (each within the scatter of the next).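

In this assay, methoxy in place of methyl on a saturated ring carbon, three ring bonds from the ring nitrogen, gives a 2.0-fold higher number from compound 2 to compound 3 (0.29 log units; within the scatter) and so leaves this ring carbon without a step beyond the scatter. 4-Methoxypiperidin-1-yl in place of azetidin-1-yl on the sulfonyl sulfur gives a 1.0-fold higher number from compound 1 to compound 3 (0.01 log units; within the scatter) and so the three groups on that sulfur all read alike within the scatter. No supporting data bear on these steps.

Open, as far as these compounds go, is whether an amine or a carboxylic acid on that ring carbon would give a step beyond the scatter.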